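The source may report more compounds than this note shows. Statements on the series, on what has been measured and on what is new or still open speak of the compounds shown alone.

Compound 1 `CC(=O)OC[C@H]1O[C@@H](n2cnc3c(N)ncnc32)[C@@H](O)[C@@H]1O` is the acetyl ester of the shared core. In a physicochemical assay for lipophilicity, using the shake flask method, in phosphate buffer, with a stated time of 1 h (a higher number here means a more lipophilic compound, a lower number a more polar compound), compound 1 gives 0.12, the lowest of the three measured values. Compound 2 `Nc1ncnc2c1ncn2[C@@H]1O[C@H](COC(=O)CCc2ccccc2)[C@@H](O)[C@@H]1O` gives 1.73 and compound 3 `CCCCCC(=O)OC[C@H]1O[C@@H](n2cnc3c(N)ncnc32)[C@@H](O)[C@@H]1O` gives 1.78 in this assay. Compound 4 `Nc1ncnc2c1ncn2[C@@H]1O[C@H](COC(=O)c2ccccc2)[C@@H](O)[C@@H]1O` differs from compound 1 by phenyl in place of methyl on a carbonyl carbon, acetyl becoming benzoyl. Going by the values given here, two measured steps bear on this: a number 1.61 log units higher from compound 1 to compound 2 (beyond the scatter) and a number 1.66 log units higher from compound 1 to compound 3 (beyond the scatter), each a large rise from adding carbon to the ester, while a number 0.05 log units higher from compound 2 to compound 3 (within the scatter) shows the shape of that carbon mattered little. A smaller net gain of carbon here suggests a rise somewhat below those two. Compound 4 is therefore expected to give 1.55, within 1.1 to 2, an estimated step of a number 1.43 log units higher from compound 1 to compound 4 (beyond the scatter).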

Compound 4, partition coefficient: 1.34
For compound 4 the middle estimate is 0.21 log units above the measured one, within the range that was stated.
By their numbers in this assay, from the lowest: compound 1; then compound 4; then compounds 2 and 3 (each within the scatter of the next).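

With phenyl on the carbonyl carbon, the number in this assay still rises, a number 1.22 log units higher from compound 1 to compound 4 (beyond the scatter), so a rise at this position does not depend on a saturated chain. The benzoyl ester nevertheless falls short of both longer esters, a number 0.44 log units lower from compound 3 to compound 4 (beyond the scatter) and a number 0.39 log units lower from compound 2 to compound 4 (beyond the scatter), a separation that the earlier esters, which lay within the scatter of each other, did not show. Nothing available explains this gap. The compounds shown leave open how an amine or a carboxylic acid on the ester group would move this number, and whether a chain longer than pentyl would raise it further.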